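The compounds below may be only part of what the source reports. "The series", "measured", "known", "first", "only" and "open" are said of these compounds alone.

Going by the values given here, compound 2, with the structure `CC(=O)Nc1ccc(-c2nc3cc(C(F)(F)F)ccc3n2C)cc1`, is one of two compounds measured so far. Among the compounds with values here, in an ADME assay on MT4 cells (Homo sapiens) for cytotoxicity, read by MTT assay, with a stated time of 96 h (a lower number here means that less compound is tolerated, a higher number that more compound is tolerated), compound 2 gives 15000 nM, the highest of the two numbers known; its only neighbour, compound 1, has the structure `Cn1c(-c2ccc(NC(=O)CN3CCCCC3)cc2)nc2cc(C(F)(F)F)ccc21` and gives 9000 nM, a gap that lies within the scatter of repeated measurements. Within the data shown here, the single measured step, a 1.7-fold higher number from compound 1 to compound 2 (0.22 log units; within the scatter), is the one that bears on what follows, as it alters the same place in the molecule.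

Compound 3, with the structure `Cn1c(-c2ccc(NC(=O)CN3CCN(c4ccccc4)CC3)cc2)nc2cc(C(F)(F)F)ccc21`, has not yet been measured. It differs from compound 2 in one place: 4-phenylpiperazin-1-yl in place of hydrogen on a saturated chain carbon bound to a carbonyl carbon. The earlier step went the other way at this place, removing piperidin-1-yl, and barely moved the number, so putting a larger group back in is expected to move it little; if anything, a modest fall is the more likely direction, but no step beyond the scatter is firmly expected. Compound 3 is therefore estimated at 7000 nM, within a range from 2500 nM to 20000 nM, which would be an expected step of a 2.1-fold lower number from compound 2 to compound 3 (0.33 log units; beyond the scatter).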

Compound 3, half-maximal cytotoxic concentration: 1500 nM
Compound 3: middle estimate off by 4.7-fold (0.67 log units), on the high side, and the stated range ends above it.
By their numbers in this assay, from the lowest: compound 3; then compounds 1 and 2 (each within the scatter of the next).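

In this assay the saturated chain carbon bound to a carbonyl carbon proves sensitive to what it carries: 4-phenylpiperazin-1-yl in place of hydrogen gives a 10-fold lower number from compound 2 to compound 3 (1.00 log units; beyond the scatter) and so goes beyond the scatter, which the earlier step at this place did not do. The comparison of the two ring groups is the more telling one, with 4-phenylpiperazin-1-yl in place of piperidin-1-yl giving a 6.0-fold lower number from compound 1 to compound 3 (0.78 log units; beyond the scatter) as well, so a ring on this carbon does not by itself lower the number, and the identity of the group matters. Nothing available explains why this group lowers the number in this way.

The compounds shown do not tell which part of 4-phenylpiperazin-1-yl goes with the lower number, the phenyl ring or the piperazine ring that carries it, and a plain piperazin-1-yl or a 4-methylpiperazin-1-yl would separate the two. As far as these compounds go, it also remains open how a morpholin-4-yl group, or a phenyl ring bearing a fluorine or a methoxy group, would read at this same place.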